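A few compounds are considered here, and "the series" means these few. Any claim that something is new, unique, unknown or untested is made for them only; others in the source may bear on it.

The measured compounds:

Compound 1 `CCCCc1c(F)c(N)c2c(=O)cc(-c3ccc(N)c(F)c3)oc2c1F`. In a functional assay on HeLa cells (Homo sapiens) for cytotoxicity, read by neutral red uptake, with a stated time of 3 days (on this read-out higher numbers stand for weaker inhibition and lower numbers for stronger inhibition), compound 1 gives > 100000 nM, which is a limit of the assay and not a number.
Compound 2 `COc1c(F)c(N)c2c(=O)cc(-c3ccc(N)c(F)c3)oc2c1F`. In this assay compound 2 gives 34000 nM.
Compound 3 `CCC(=O)OCc1c(F)c(N)c2c(=O)cc(-c3ccc(N)c(F)c3)oc2c1F`. In this assay compound 3 gives 69000 nM.

Compound 3 stands highest of the two numbers shown, with compound 2 nearest: a 2.0-fold higher number from compound 2 to compound 3 (0.31 log units; beyond the scatter). The remaining value, that of compound 1, is a limit (the limit of > 100000 nM in this assay, at which 1 of the 3 values shown sits), and from it an at least 1.4-fold lower number from compound 1 to compound 3 (0.16 log units; that floor lies within the scatter).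

Compound 4 `CCCCCCOCc1c(F)c(N)c2c(=O)cc(-c3ccc(N)c(F)c3)oc2c1F` differs from compound 3 in one place: hexyl in place of propanoyl on an oxygen on a saturated carbon. Within the data shown here, no measured step makes this same change. The step closest in kind is an at least 1.4-fold lower number from compound 1 to compound 3 (0.16 log units; that floor lies within the scatter), which runs the other way, from a plain chain to an ester, and its floor lies within the scatter; the step of a 2.0-fold higher number from compound 2 to compound 3 (0.31 log units; beyond the scatter) is also modest. Compound 4 carries a plain chain on the oxygen, much as compound 1 carries a plain chain on the ring, and compound 1 reaches only the limit (the limit of > 100000 nM in this assay, at which 1 of the 3 values shown sits). The expected step is therefore a 1.4-fold higher number from compound 3 to compound 4 (0.16 log units; within the scatter), toward a higher number, with a fair chance that compound 4 also reaches only the limit. Compound 4 is estimated at 100000 nM, in the range 40000 nM to 250000 nM.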

Compound 4, half-maximal inhibitory concentration: > 100000 nM
Compound 4 gave a limit, no number (the forecaster's own chance of this, stated with the estimate: 50%); the middle value sits exactly at the limit.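

In this assay the result for compound 4 is a limit of the assay and not a number, so the change from propanoyl to hexyl on this oxygen gives only a floor (an at least 1.4-fold higher number from compound 3 to compound 4 (0.16 log units; that floor lies within the scatter)), and that floor does not separate the ether from the ester. The change from methoxy to (hexyloxy)methyl can be read beyond the scatter (an at least 2.9-fold higher number from compound 2 to compound 4 (0.46 log units; beyond the scatter)), so this plain ether chain, like the butyl of compound 1, stands apart from methoxy toward higher numbers. The step between compound 1 and compound 4 cannot be read, since both sit at the same limit: the limit of > 100000 nM in this assay, at which 2 of the 4 values shown sit.

Going by these compounds, it remains open whether a shorter chain such as ethyl on this oxygen would give a number within range. On these data alone, it is also open whether an amine or a carboxylic acid at the end of the hexyl chain would do so in this assay.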